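A few compounds are considered here, and "the series" means these few. Any claim that something is new, unique, unknown or untested is made for them only; others in the source may bear on it.

Four compounds share one core and differ only in one group on it. Compound 1 `Cc1ccccc1-n1nc(C)c2c1NC(=O)[C@H](C)S[C@@H]2c1ccc(-c2cc3ccccc3o2)cc1` carries a 1-benzofuran-2-yl group, compound 2 `Cc1ccccc1-n1nc(C)c2c1NC(=O)[C@H](C)S[C@@H]2c1ccc(-c2ccsc2)cc1` a thiophen-3-yl group, compound 3 `Cc1ccccc1-n1nc(C)c2c1NC(=O)[C@H](C)S[C@@H]2c1ccc(Oc2cccc(C(=O)O)c2)cc1` a 3-carboxyphenoxy group and compound 4 `Cc1ccccc1-n1nc(C)c2c1NC(=O)[C@H](C)S[C@@H]2c1ccc(Oc2ccccc2C(=O)O)cc1` a 2-carboxyphenoxy group.

In an assay on isolated protein for agonist activity at Bile acid receptor (Homo sapiens), read by AlphaScreen, with a stated time of 30 min (on this read-out lower numbers stand for an effect already at smaller amounts and higher numbers for an effect only at larger amounts of compound), compound 1 gives 1500 nM and compound 2 gives 1400 nM; the step of a 1.1-fold lower number from compound 1 to compound 2 (0.03 log units; within the scatter) shows that these two cannot be told apart. In this assay compound 3 gives "not active" (no number reported), so no number places it at all; the only thing known is that it behaves differently from compounds 1 and 2.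

Compound 4 differs from compound 3 by 2-carboxyphenyl in place of 3-carboxyphenyl on an oxygen on an aromatic ring. Within the data shown here, the single measured step concerns another part of the molecule, so no measured step bears on this change. The same atoms are kept and only rearranged, and the nearest relative, compound 3, gives "not active" (no number reported). Compound 4 is therefore expected to stay weak, with an estimated 20000 nM in this assay, in a range from 4000 nM to 100000 nM, and a sizeable chance that again no number can be given.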

Compound 4, half-maximal effective concentration: "not active" (no number reported)
The entry for compound 4 holds no number; no gap can be computed for the estimate.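

In this assay, compound 3 and compound 4 both read as "not active", so no step can be read between them. The compounds shown leave open how the 3-carboxyphenoxy and 2-carboxyphenoxy groups compare in size of effect. No available evidence bears on this result.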